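The compounds below may be only part of what the source reports. "The series", "measured", "known", "first", "only" and "open" are said of these compounds alone.

Compound 1, with the structure `COc1ccc2nc(Nc3ccnc(Nc4ccc(S(N)(=O)=O)cc4)n3)sc2c1`, stands lowest of the two numbers recorded in a functional assay on HeLa cells (Homo sapiens) for antiproliferative activity, read by MTT assay, with a stated time of 48 h; a lower number here means a stronger inhibitor, a higher number a weaker inhibitor: compound 1 gives 1730 nM. Its nearest companion is compound 3, with the structure `Cc1ccc2nc(Nc3ccnc(Nc4ccc(S(C)(=O)=O)cc4)n3)sc2c1`, which in this assay gives 2300 nM; the gap between these two values is within the usual scatter, so neither can be called the stronger. Compound 2, with the structure `Cc1cnc(Nc2ccc(Cl)cc2)nc1Nc1nc2ccccc2s1`, belongs to the same family but in this assay gives only a limit, > 50000 nM, rather than a number. That one of the three values in this assay sits at such a limit is recorded as the limit of > 50000 nM in this assay, at which 1 of the 3 values shown sits.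

The next compound to be examined is compound 4, with the structure `NS(=O)(=O)c1ccc(Nc2nccc(Nc3nc4ccc(F)cc4s3)n2)cc1`. Compared with compound 1 the change is a single small one: fluoro in place of methoxy on an aromatic carbon. Both groups sit on an aromatic carbon of a six-membered aromatic ring of carbon only, part of a fused or bridged system of two rings.

No measured pair among these compounds shows what such a swap does in this assay, so no step beyond the scatter is expected in either direction. Compound 4 is therefore estimated at 2000 nM, with a plausible range from 700 nM to 6000 nM, which would correspond to a step of a 1.2-fold higher number from compound 1 to compound 4 (0.06 log units; within the scatter).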

Compound 4, half-maximal inhibitory concentration: 450 nM
For compound 4 the middle estimate is 4.4-fold (0.65 log units) above the measured one, and the stated range ends above it.
By their numbers in this assay, from the lowest: compound 4; then compounds 1 and 3 (each within the scatter of the next). At a limit, above all of these: compound 2.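

Going by these compounds alone, this is the first measured step at this position on the core: in this assay, fluoro in place of methoxy gives a 3.8-fold lower number from compound 1 to compound 4 (0.58 log units; beyond the scatter). The earlier compounds shown here could not show this, as none of them formed a pair differing in one place, so it was open whether a group on this aromatic carbon mattered at all in this assay. The swap is small by count, with a single fluorine atom entering where a carbon and an oxygen leave and the hydrogen-bond acceptor of the methoxy going with them, yet the step lies beyond the scatter, and nothing measured here explains why the number falls.

From the compounds shown here alone, one pair cannot separate what fluoro adds from what the loss of methoxy removes, so it remains open whether fluoro itself matters or whether other small groups on this carbon, such as a nitrile, a trifluoromethyl or an amine, would give a similar number. Going by these compounds, it is also open whether the same swap would give a similar step on a compound with a different group in place of the sulfonamide of compound 4.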